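Amide nitrogen substituents in a nitro-chromene series

A few compounds are considered here, and "the series" means these few. Any claim that something is new, unique, unknown or untested is made for them only; others in the source may bear on it.

Measured in a functional assay on the whole organism (muscle tissue) with Rattus norvegicus as the target; a lower number here means a smaller maximal response, a higher number a larger maximal response:
compound 1, `CCNC(=O)C1=CC(C)(C)Oc2ccc([N+](=O)[O-])cc21`: 80.5%
compound 2, `CC1(C)C=C(C(=O)NCC2CC2)c2cc([N+](=O)[O-])ccc2O1`: 89.3%
compound 3, `CC1(C)C=C(C(=O)NCCC#N)c2cc([N+](=O)[O-])ccc2O1`: 73.1%

Compound 3 has the lowest of the three numbers in this assay; the gap to compound 1 is within the scatter, as a number 7.4 percentage points lower from compound 1 to compound 3 (within the scatter) shows, while the gap to compound 2 lies beyond it, as a number 16.2 percentage points lower from compound 2 to compound 3 (beyond the scatter) shows. Compound 4, `CC1(C)C=C(C(N)=O)c2cc([N+](=O)[O-])ccc2O1`, differs from compound 3 as follows: hydrogen in place of 2-cyanoethyl on an amide-type nitrogen. Within the data shown here, both measured steps alter only the chain on the amide nitrogen; no step removes that chain altogether, so the change to compound 4 is only loosely covered. The chain variants span a modest range, and no step beyond the scatter is expected. Compound 4 is therefore estimated at 78%, within 62% to 92%, meaning an expected step of a number 4.9 percentage points higher from compound 3 to compound 4 (within the scatter).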

Compound 4, intrinsic activity: the largest response reached, in percent of the reference agonist's: 79.8%
Estimate against measurement, compound 4: 1.8 percentage points below; the measured number falls inside the stated range.
By their numbers in this assay, from the lowest: compounds 3, 4, 1 and 2 (each within the scatter of the next, the first and the last beyond it).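

Compound 4, which carries only hydrogen on the amide nitrogen, stands within the scatter of all three compounds with a chain in this assay (a number 6.7 percentage points higher from compound 3 to compound 4 (within the scatter); a number 9.5 percentage points lower from compound 2 to compound 4 (within the scatter); a number 0.7 percentage points lower from compound 1 to compound 4 (within the scatter)). A chain on this nitrogen is therefore not required for a large maximal response here, and the only gap beyond the scatter remains that between the cyclopropylmethyl of compound 2 and the 2-cyanoethyl of compound 3. No evidence on the reason for these numbers is at hand.

Still open, from the compounds shown here alone, is whether a longer chain, a benzyl group or a second ethyl on the same nitrogen would stay in this range. Replacing the amide with a carboxylic acid is equally unresolved.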